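Swapping the Aryl Group on the Saturated Ring Carbon

The source may report more compounds than this note shows. Statements on the series, on what has been measured and on what is new or still open speak of the compounds shown alone.

Of the compounds shown here, three sharing one core have been measured in an assay on cells for inhibition of histone deacetylase 4 (Homo sapiens), read by fluorescence, with a stated time of 30 min; a higher number here means a weaker inhibitor, a lower number a stronger inhibitor. Compound 1 `O=C1NC(=O)/C(=C\c2ccc(OCC(=O)N3N=C(c4ccccc4)CC3c3ccccc3Cl)cc2)S1` gives 1200 nM, compound 2 `O=C1NC(=O)/C(=C\c2ccc(OCC(=O)N3N=C(c4ccccc4)CC3c3ccc(F)cc3)cc2)S1` gives 1700 nM, and compound 3 `O=C1NC(=O)/C(=C\c2ccc(OCC(=O)N3N=C(c4ccccc4)CC3c3ccc(F)cc3F)cc2)S1` gives 2200 nM, the highest of the three numbers, although both gaps, a 1.8-fold higher number from compound 1 to compound 3 (0.26 log units; within the scatter) and a 1.3-fold higher number from compound 2 to compound 3 (0.11 log units; within the scatter), stay within the scatter. Compound 4 `Cc1ccc(C2CC(c3ccccc3)=NN2C(=O)COc2ccc(/C=C3/SC(=O)NC3=O)cc2)cc1` is not yet measured; it differs from compound 3 by 4-methylphenyl in place of 2,4-difluorophenyl on a saturated ring carbon. Among the compounds with values here, the steps that bear on this change, a 1.4-fold higher number from compound 1 to compound 2 (0.15 log units; within the scatter), a 1.8-fold higher number from compound 1 to compound 3 (0.26 log units; within the scatter) and a 1.3-fold higher number from compound 2 to compound 3 (0.11 log units; within the scatter), all alter the group on that same saturated ring carbon, and none leaves the scatter. Compound 4 is therefore expected to show a 1.2-fold lower number from compound 3 to compound 4 (0.09 log units; within the scatter), nothing beyond the scatter. Compound 4 is estimated at 1800 nM, with a range from 900 nM to 3600 nM.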

Compound 4, half-maximal inhibitory concentration: 1200 nM
Beside the measured number, compound 4's estimate is 1.5-fold (0.18 log units) above it; low and high end bracket the measured number.
By their numbers in this assay, from the lowest: compounds 1, 4, 2 and 3 (each within the scatter of the next).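

In this assay the 4-methylphenyl group on this saturated ring carbon stays within the scatter of all three aryl groups shown earlier (a 1.8-fold lower number from compound 3 to compound 4 (0.26 log units; within the scatter); a 1.4-fold lower number from compound 2 to compound 4 (0.15 log units; within the scatter); no change at the digits printed from compound 1 to compound 4 (within the scatter)). The position therefore now carries a carbon-only substituent on its phenyl ring as well as chloro and fluoro ones, and methyl in place of fluoro on an aromatic carbon does not leave the scatter. Nothing available here explains why these groups read alike. Still open, as far as these compounds go, is whether an amine or a carboxylic acid in place of the aryl group on this saturated ring carbon would give a number beyond the scatter.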